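A few compounds are considered here, and "the series" means these few. Any claim that something is new, unique, unknown or untested is made for them only; others in the source may bear on it.

Compound 2 `CCn1c(=O)/c(=C2\Sc3ccccc3N2C)s/c1=C\c1ccncc1Nc1ccccc1C` gives 470 nM in a functional assay on CWR22R cells (Homo sapiens) for inhibition (on this read-out higher numbers stand for weaker inhibition and lower numbers for stronger inhibition), the lowest of the two numbers measured; compound 1 `CCn1c(=O)/c(=C2\Sc3ccccc3N2C)s/c1=C\c1ccncc1Nc1cc(C)ccc1C` gives 1800 nM. Among the compounds with values here, the only measured step, a 3.8-fold lower number from compound 1 to compound 2 (0.58 log units; beyond the scatter), swaps hydrogen for methyl on an aromatic carbon and bears only loosely on the change to compound 3 `CCn1c(=O)/c(=C2\Sc3ccccc3N2C)s/c1=C\c1ccncc1Nc1cc(F)ccc1F`, which is 2,5-difluorophenyl in place of 2-methylphenyl on a nitrogen on an aromatic ring. Within the data shown here, no measured step shows a fluorine for methyl exchange, so the expectation is a step of a 1.3-fold higher number from compound 2 to compound 3 (0.11 log units; within the scatter) in this assay, lying within the usual scatter. Compound 3 is therefore estimated at 600 nM, with a range from 200 nM to 1800 nM.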

Compound 3, half-maximal inhibitory concentration: 1100 nM
Beside the measured number, compound 3's estimate is 1.8-fold (0.26 log units) below it, and the stated range covers the measured number.
By their numbers in this assay, from the lowest: compound 2; then compounds 3 and 1 (each within the scatter of the next).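

In this assay, the step of a 2.3-fold higher number from compound 2 to compound 3 (0.37 log units; beyond the scatter) shows that 2,5-difluorophenyl gives weaker inhibition than 2-methylphenyl on this nitrogen. The step of a 1.6-fold lower number from compound 1 to compound 3 (0.21 log units; within the scatter) does not separate 2,5-difluorophenyl from 2,5-dimethylphenyl, so the two fluorines and the two methyls read alike in this pair. Nothing measured here explains either step.

The compounds shown leave open how an unsubstituted phenyl ring would compare with compound 2. They also leave open what an amine or a carboxylic acid on this ring would do.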